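A few compounds are considered here, and "the series" means these few. Any claim that something is new, unique, unknown or untested is made for them only; others in the source may bear on it.

Of the compounds shown here, three that share one core have been tested in a functional assay on HEK293 cells for agonist activity at Bombesin receptor subtype-3 (Homo sapiens), read by luminescence and calcium flux, with a stated time of 10 min; a higher number here means that more compound is needed for the effect, a lower number that less compound is needed. Compound 1 `CCC(C)(C)Cc1c[nH]c(CCc2ccc(-c3ccncc3)cc2)n1` gives 95 nM. Compound 2 `CCC(C)(C)Cc1c[nH]c(CCc2ccc(-n3ccnn3)cc2)n1` gives 93 nM in this assay, and compound 3 `CCC(C)(C)Cc1c[nH]c(CCc2ccc(-c3ccccc3C(=O)O)cc2)n1` gives 101 nM. Compound 2 has the lowest of the three numbers, yet all three sit within the usual scatter of one another, so the three compounds behave alike here. The steps between them show this directly: a 1.0-fold lower number from compound 1 to compound 2 (0.01 log units; within the scatter), a 1.1-fold higher number from compound 1 to compound 3 (0.03 log units; within the scatter), and a 1.1-fold higher number from compound 2 to compound 3 (0.04 log units; within the scatter).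

Compound 4 `CCC(C)(C)Cc1c[nH]c(CCc2ccc(-c3cccc(N)n3)cc2)n1` has not yet been measured. It differs from compound 2 in one place: 6-aminopyridin-2-yl in place of 1H-1,2,3-triazol-1-yl on an aromatic carbon. All three measured steps swap the group on that same aromatic carbon, and three quite different groups leave the numbers almost unchanged. Those steps bear on the new change, and the expected outcome is a step of no size beyond the scatter: the expected step is a 1.1-fold higher number from compound 2 to compound 4 (0.03 log units; within the scatter). Compound 4 is therefore estimated at 100 nM in this assay, with a range from 40 nM to 250 nM.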

Compound 4, half-maximal effective concentration: 97 nM
Compound 4: the middle estimate sits 1.0-fold (0.01 log units) above what was measured; the range from low to high includes it.
By their numbers in this assay, from the lowest: compounds 2, 1, 4 and 3 (each within the scatter of the next).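

In this assay, the aromatic carbon para to a large group now carries a fourth group, 6-aminopyridin-2-yl, and every new comparison stays within the scatter: a 1.0-fold higher number from compound 2 to compound 4 (0.02 log units; within the scatter) and a 1.0-fold higher number from compound 1 to compound 4 (0.01 log units; within the scatter) and a 1.0-fold lower number from compound 3 to compound 4 (0.02 log units; within the scatter). Replacing the five-membered 1H-1,2,3-triazol-1-yl with this six-membered ring, which has 1 hydrogen-bond donor, therefore makes no measurable difference, and the four groups shown cannot be told apart at this position. Nothing measured here explains why they read alike. From the compounds shown here alone, all four groups contain an aromatic ring, so it remains open whether a small amine, a carboxylic acid attached directly to that carbon or a longer alkyl chain would read the same. Changes elsewhere on the shared core also remain open.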